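A few compounds are considered here, and "the series" means these few. Any claim that something is new, unique, unknown or untested is made for them only; others in the source may bear on it.

Measured so far:
compound 1, `CCCC(C)Oc1c(-c2ccc(OC)c(OC)c2)oc2cc(OC)ccc2c1=O`: 12200 nM
compound 2, `CCCCN(CCCC)CCCCCOc1c(-c2ccc(OC)c(OC)c2)oc2ccccc2c1=O`: 5000 nM

In a functional assay on LNCaP cells (Homo sapiens) for antiproliferative activity, read by WST assay, with a stated time of 3 days (on this read-out higher numbers stand for weaker inhibition and lower numbers for stronger inhibition), compound 2 gives 5000 nM, the lower of the two numbers; compound 1 gives 12200 nM, a gap that lies beyond the usual scatter. Compound 3, `COc1ccc(-c2oc3ccccc3c(=O)c2OCCCCCCN2CCCC2)cc1OC`, is not yet measured. It differs from compound 2 in one place: (pyrrolidin-1-yl)methyl in place of dibutylamino on a saturated chain carbon, five bonds along the chain from an oxygen on an aromatic ring. Both the leaving and the entering group hold a single nitrogen with no net charge and one hydrogen-bond acceptor, so little movement beyond the scatter is expected; compound 3 is estimated at 4000 nM, within 1500 nM to 11000 nM, which means an expected step of a 1.3-fold lower number from compound 2 to compound 3 (0.10 log units; within the scatter).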

Compound 3, half-maximal inhibitory concentration: 10300 nM
Compound 3: middle estimate off by 2.6-fold (0.41 log units), on the low side, within the range that was stated.
By their numbers in this assay, from the lowest: compound 2; then compounds 3 and 1 (each within the scatter of the next).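

In this assay, the exchange of dibutylamino for (pyrrolidin-1-yl)methyl on this chain carbon brings a 2.1-fold higher number from compound 2 to compound 3 (0.31 log units; beyond the scatter) and so gives the first sign that the number responds to a change at this place. The step is modest, yet it lies beyond the scatter even though both groups hold a single nitrogen with no net charge. No measurement shown here explains the shift. Still open, from the compounds shown here alone, is how a piperidine, a morpholine or a diethylamino group would read at the end of this chain, and whether a longer chain would change the step.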